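Methoxybenzyl versus tert-butyl on the shared core

The source may report more compounds than this note shows. Statements on the series, on what has been measured and on what is new or still open speak of the compounds shown alone.

Compound 2 `CC(C)(C)c1cnc(CCc2ccc(-c3ccccc3C(=O)O)cc2)[nH]1` carries a tert-butyl group on the shared core. In an in vitro functional assay on cells for agonist activity at Bombesin receptor subtype-3 (Mus musculus), read by luminescence and calcium flux (on this read-out lower numbers stand for an effect already at smaller amounts and higher numbers for an effect only at larger amounts of compound), compound 2 gives 2750 nM, the highest of the two numbers recorded so far. Its nearest measured neighbour is compound 1 `COc1cccc(Cc2cnc(CCc3ccc(-c4ccccc4C(=O)O)cc3)[nH]2)c1`, which in this assay gives 79 nM; the gap between them is a 35-fold higher number from compound 1 to compound 2 (1.54 log units; beyond the scatter).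

Compound 3 `COc1ccccc1Cc1cnc(CCc2ccc(-c3ccccc3C(=O)O)cc2)[nH]1` is the next compound to be measured. It differs from compound 2 in one place: 2-methoxybenzyl in place of tert-butyl on an aromatic carbon. Within the data shown here, the only measured step that bears on this change is a 35-fold higher number from compound 1 to compound 2 (1.54 log units; beyond the scatter), which removed a methoxybenzyl group in favour of tert-butyl and produced a large rise in the number. The present change reverses that exchange, with the methoxy group now on a different position of the benzyl ring, so a large step downward is expected, of a size close to the earlier one but with added uncertainty for the altered methoxy placement. For compound 3 the expected step is a 23-fold lower number from compound 2 to compound 3 (1.36 log units; beyond the scatter). In this assay compound 3 is therefore estimated at 120 nM, within the range 40 nM to 400 nM.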

Compound 3, half-maximal effective concentration: 163 nM
Compound 3: the middle estimate sits 1.4-fold (0.13 log units) below what was measured; the range from low to high includes it.
By their numbers in this assay, from the lowest: compound 1; then compound 3; then compound 2.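

In this assay, a 17-fold lower number from compound 2 to compound 3 (1.23 log units; beyond the scatter) shows that the advantage over tert-butyl at this aromatic carbon of the five-membered ring does not depend on the 3-methoxybenzyl group alone, as a 2-methoxybenzyl group there recovers most of the gap opened by compound 2. The placement of the methoxy group on the benzyl ring still counts, but far less than the exchange of the whole group: a 2.1-fold higher number from compound 1 to compound 3 (0.31 log units; beyond the scatter) is modest and lies just beyond the scatter, whereas the replacement of tert-butyl is a large step. No supporting measurement is available to explain either step.

The compounds shown leave open whether the gain over tert-butyl comes from the benzyl ring, the methoxy group or the larger size of the entering group, a question that an unsubstituted benzyl group would help to separate. A cyclohexylmethyl group would test whether the ring needs to be aromatic, and a hydroxyl or fluorine in place of the methoxy group would test whether the oxygen-linked methyl is needed at all.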